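The compounds below may be only part of what the source reports. "The series", "measured", "known", "first", "only" and "open" are said of these compounds alone.

Measured so far in an ADME assay on J774.1 cells (Mus musculus) for cytotoxicity, with a stated time of 48 h; a higher number here means that more compound is needed for the effect, a lower number that less compound is needed:

- compound 1 `COC(=O)c1c(-c2ccccn2)n(Cc2ccc(Cl)cc2)c(-c2ccccn2)cc1=O`: > 100 uM, a limit of the assay
- compound 2 `COC(=O)C1C(=O)C(C(=O)OC)[C@H](c2cccc([N+](=O)[O-])c2)N(Cc2ccc(OC)cc2)[C@@H]1c1cccc([N+](=O)[O-])c1`: > 100 uM, a limit of the assay
- compound 3 `C=CCN1[C@H](c2ccc([N+](=O)[O-])cc2)C(C(=O)OC)C(=O)C(C(=O)OC)[C@@H]1c1ccc([N+](=O)[O-])cc1`: 50.3 uM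

Compound 2 stands at the limit of > 100 uM in this assay, at which 2 of the 3 values shown sit; no number is known for it in this assay. Among the measured compounds shown here, compound 3 is the only value that is a number.

Compound 4 `COC(=O)C1C(=O)C(C(=O)OC)[C@H](c2cccc([N+](=O)[O-])c2)N(Cc2ccc(C)cc2)[C@@H]1c1cccc([N+](=O)[O-])c1` is not yet measured. It differs from compound 2 by methyl in place of methoxy on an aromatic carbon, a methyl in place of methoxy on an aromatic carbon. For the measured compounds named here, no measured pair isolates such a change, so the expected step of a number no higher from compound 2 to compound 4 (the limit leaves the size open) is none beyond the scatter, with a good chance that only a limit is again reported. Compound 4 is expected at 100 uM, within 40 uM to 250 uM.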

Compound 4, concentration for half-maximal effect: 49.8 uM
For compound 4 the middle estimate is 2.0-fold (0.30 log units) above the measured one, and the stated range covers the measured number.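

In this assay, among the compounds shown here, the change from 4-methoxybenzyl to 4-methylbenzyl gives the first readable step at this position: an at least 2.0-fold lower number from compound 2 to compound 4 (0.30 log units; that floor lies within the scatter). Compound 4 thus provides a number where the methoxy analogue provides none. The size of the step stays open because compound 2 is only a limit of the assay: the limit of > 100 uM in this assay, at which 2 of the 4 values shown sit.

Whether the true step lies beyond the scatter remains unresolved. Also open, as far as these compounds go, is what a hydroxyl, an amine or a longer chain on this aromatic carbon would give, and whether the methyl-for-methoxy step holds with other aryl groups on the shared core.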